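Cyano in Place of Isopropyl on the Terminal Ring

This account rests on a few compounds, and the source may have more. Where it says the series, first, only, none or still open, it means among the compounds named here.

Among the measured compounds shown here, compound 2 `CC#C[C@@H](CC(=O)O)c1ccc(OCc2ccc3nc(-c4ccc(C(C)C)cc4)nn3c2)cc1` gives the lowest of the two numbers known, at 2 nM in a functional assay on HEK293 cells for agonist activity at Free fatty acid receptor 1 (Homo sapiens), read by FLIPR and calcium flux, with stated times of 2.5 h and 3 min; a lower number here means that less compound is needed, a higher number that more compound is needed for the effect. Its nearest neighbour is compound 1 `CC#C[C@@H](CC(=O)O)c1ccc(OCc2ccc3nc(-c4c(C)cc(OCCCS(C)(=O)=O)cc4C)nn3c2)cc1`, which in this assay gives 117 nM, a gap beyond the scatter; the two differ in more than one place, so only their values are set side by side. Compound 3 `CC#C[C@@H](CC(=O)O)c1ccc(OCc2ccc3nc(-c4ccc(C#N)cc4)nn3c2)cc1` has not yet been measured. It differs from compound 2 by a single change: cyano in place of isopropyl on an aromatic carbon, so that 4-isopropylphenyl becomes 4-cyanophenyl, the new group sitting para to a large group. For the measured compounds named here, no single-point step between measured compounds exists to guide the expectation. Compound 3 is estimated to need somewhat more compound than compound 2, because compound 2 gives 2 nM and the step expected here is a 4.0-fold higher number from compound 2 to compound 3 (0.60 log units; beyond the scatter). For compound 3 the estimate is 8 nM, within a range from 2 nM to 40 nM.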

Compound 3, half-maximal effective concentration: 9 nM
The estimate for compound 3 lay 1.1-fold (0.05 log units) below the measured number, and the stated range covers the measured number.
By their numbers in this assay, from the lowest: compound 2; then compound 3; then compound 1.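

In this assay, among the compounds shown here, the change from 4-isopropylphenyl to 4-cyanophenyl gives the first single-place step at this position: a 4.5-fold higher number from compound 2 to compound 3 (0.65 log units; beyond the scatter). The step is beyond the scatter but modest, and with cyano, which brings one hydrogen-bond acceptor and one heavy atom fewer than isopropyl, compound 3 still gives 9 nM, so this position on the aromatic ring, para to a large group, accepts a quite different group at a modest cost. Nothing measured here accounts for the size of this step.

The compounds shown leave open how other groups at this place would compare, such as a methoxy group, a chlorine atom, an amine or a tert-butyl group. They also leave open whether the same exchange would give a step of similar size on a terminal ring carrying the other groups found in compound 1.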